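Swapping a Methyl for a Nitro on Compound 2

The compounds below may be only part of what the source reports. "The series", "measured", "known", "first", "only" and "open" are said of these compounds alone.

Three close relatives of one shared core have been tested in a functional assay on HepG2 cells (Homo sapiens) for inhibition, read by MTT assay, with a stated time of 72 h; a higher number here means a weaker inhibitor, a lower number a stronger inhibitor. Compound 1 `C#CCSc1nc(NCCC#N)c2ccncc2n1` gives only a limit of the assay, > 80000 nM, as noted in the limit of > 80000 nM in this assay, at which 1 of the 3 values shown sits. Compound 2 `C#CCSc1nc(Nc2ccc(C)cc2)c2ccncc2n1` gives 6170 nM, and compound 3 `C#CCSc1nc(Nc2ccccc2Cl)c2ccncc2n1` gives 17200 nM. For the measured compounds named here, of the two real numbers, compound 2 stands lowest, and the one other number, compound 3, sits apart from it: a 2.8-fold higher number from compound 2 to compound 3 (0.45 log units; beyond the scatter).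

Compound 4 `C#CCSc1nc(Nc2ccc([N+](=O)[O-])cc2)c2ccncc2n1` has not yet been measured. It differs from compound 2 in one place: nitro in place of methyl on an aromatic carbon.

Two of the measured steps, an at least 12-fold lower number from compound 1 to compound 2 (1.11 log units; beyond the scatter) and an at least 4.6-fold lower number from compound 1 to compound 3 (0.66 log units; beyond the scatter), replace 2-cyanoethyl on a nitrogen on an aromatic ring with 4-methylphenyl or 2-chlorophenyl, a far larger change than the one in hand. The closest comparison is a 2.8-fold higher number from compound 2 to compound 3 (0.45 log units; beyond the scatter), where one phenyl group is traded for another and the number moves modestly. Going by the values given here, no measured pair trades nitro for methyl, so the direction cannot be read off the data. A step of about that modest size is therefore expected in this assay, with a small rise judged somewhat more likely than a fall. Compound 4 is estimated at 8000 nM, within 2500 nM to 25000 nM, which means an expected step of a 1.3-fold higher number from compound 2 to compound 4 (0.11 log units; within the scatter).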

Compound 4, half-maximal inhibitory concentration: > 80000 nM
Compound 4 ended at the assay's limit; the forecaster's own chance of this, stated with the estimate: 3%; middle value at least 10-fold (1.00 log units) away from the limit.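

Until this point, every step but one swapped the whole group on the nitrogen, and the step between compound 2 and compound 3 changed both the group on the phenyl ring and its place. Here the phenyl ring stays, and only the group on an aromatic carbon, para to a large group, changes: nitro in place of methyl gives an at least 12-fold higher number from compound 2 to compound 4 (1.11 log units; beyond the scatter), so a phenyl ring on that nitrogen is not enough on its own to give a measurable number in this assay. Compound 4 gives > 80000 nM, which is a limit of the assay and not a number, so the step shows only a minimum size, and this limit now recurs in the small set: the limit of > 80000 nM in this assay, at which 2 of the 4 values shown sit.

The compounds shown leave open whether the outcome belongs to nitro in particular or would follow from replacing methyl with other groups, and an amine, a methoxy group or a plain hydrogen on this same carbon would separate those two readings. They also leave open whether a longer chain, such as ethyl or propyl, in place of methyl would keep a number close to that of compound 2.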